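The source may hold more compounds than are shown below. What is called first, only, known or untested is meant among the compounds shown, and "the series" means these compounds.

Compound 1 `C#CCn1cc(C(=O)NC(CC(=O)Nc2ccccc2)c2ccccc2)c(=O)c2cc(F)c(Cl)nc21`: 5700 nM
Compound 2 `C#CCn1cc(C(=O)NC(CC(=O)Nc2ccccc2)c2ccccc2)c(=O)c2ccc(Cl)nc21`: 2900 nM

Both numbers come from a functional assay on SW-620 cells (Homo sapiens) for cytotoxicity, read by MTT assay, with a stated time of 72 h; a higher number here means a weaker inhibitor, a lower number a stronger inhibitor. Compound 1 gives 5700 nM there, the highest of the two numbers shown; its nearest neighbour is compound 2, and the step between them, a 2.0-fold lower number from compound 1 to compound 2 (0.29 log units; within the scatter), lies within the scatter, so the two compounds cannot be separated on these data. Within the data shown here, that single step is the only measured comparison available, and it concerns a change at a different place in the shared core.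

Compound 3 `C#CCn1cc(C(=O)NC(CC(=O)Nc2ccccn2)c2ccccc2)c(=O)c2cc(F)c(Cl)nc21` has not yet been measured. It differs from compound 1 in one place: pyridin-2-yl in place of phenyl on an amide-type nitrogen. Among the measured compounds shown here, no measured step touches this amide-type nitrogen or the aromatic ring attached to it, so there is nothing to show whether exchanging one six-membered aromatic ring for another here moves the number at all. The neutral expectation is a step no larger than the scatter, in either direction. On that basis compound 3 is estimated at 5000 nM in this assay, with a range from 2000 nM to 14000 nM. As a step, this estimate means a 1.1-fold lower number from compound 1 to compound 3 (0.06 log units; within the scatter), expected to stay within the scatter.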

Compound 3, half-maximal inhibitory concentration: 2300 nM
Compound 3: the middle estimate sits 2.2-fold (0.34 log units) above what was measured; the measured number falls inside the stated range.
By their numbers in this assay, from the lowest: compounds 3, 2 and 1 (each within the scatter of the next, the first and the last beyond it).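

In this assay, among these compounds, the aromatic ring on the amide-type nitrogen proves able to move the number: the step, a 2.5-fold lower number from compound 1 to compound 3 (0.39 log units; beyond the scatter), is modest but clears the usual scatter, which the one earlier step, at a different place in the shared core, did not. The change itself is small, since phenyl and pyridin-2-yl have the same count of heavy atoms and both are a single six-membered aromatic ring, but pyridin-2-yl carries one ring nitrogen and one hydrogen-bond acceptor where phenyl has none. Nothing measured here explains why this exchange lowers the number.

The compounds shown leave open whether the same exchange would lower the number on the core of compound 2, which has hydrogen in place of fluoro. They also leave open whether the location of the ring nitrogen matters, as pyridin-3-yl or pyridin-4-yl could show, and whether this amide-type nitrogen needs an aromatic ring at all, which a saturated ring such as cyclohexyl could test.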